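A few compounds are considered here, and "the series" means these few. Any claim that something is new, unique, unknown or untested is made for them only; others in the source may bear on it.

Compound 1, `O=S(=O)(c1ccc(F)cc1)c1cnc2ccc(Cl)cc2c1-c1ccc(Cl)cc1`, was run in an ADME assay on microsomes from liver (Homo sapiens) for metabolic stability, tested at 2.5 uM (a higher number here means faster removal of the compound, a lower number slower removal), where compound 1 gives 0.01 mL/min. Two close relatives have also been measured. Compound 2, `O=S(=O)(c1ccc(F)cc1)c1cnc2cc(F)c(Cl)cc2c1-c1ccc(Cl)cc1`, gives 0.01 mL/min in this assay, and compound 3, `O=S(=O)(c1ccc(F)cc1)c1cnc2ccc(F)cc2c1-c1ccc(Cl)cc1`, gives 0.12 mL/min. Compound 1 thus sits level with compound 2 at the digits shown, the two together the lowest of the three numbers, with compound 3 the furthest away: a 12-fold higher number from compound 1 to compound 3 (1.08 log units; beyond the scatter).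

The unmeasured compound 4, `O=S(=O)(c1ccc(F)cc1)c1cnc2c(F)cc(Cl)cc2c1-c1ccc(Cl)cc1`, differs from compound 1 in a single way: fluoro in place of hydrogen on an aromatic carbon. The step that bears most directly on this change is the one of the same kind, fluoro in place of hydrogen on an aromatic carbon, seen from compound 1 to compound 2, which gave no change at the digits printed from compound 1 to compound 2 (within the scatter). The large step to compound 3 belongs to a different change, fluoro in place of chloro, and so says little here. On this basis the expectation for compound 4 is a step of a 1.5-fold higher number from compound 1 to compound 4 (0.18 log units; within the scatter), that is, nothing beyond the scatter. Compound 4 is therefore estimated at 0.015 mL/min, within a range of 0.005 mL/min to 0.04 mL/min.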

Compound 4, intrinsic clearance in a liver preparation (reported as CLH), per the amount of preparation that the assay uses: 0.01 mL/min
Beside the measured number, compound 4's estimate is 1.5-fold (0.18 log units) above it, and the stated range covers the measured number.
By their numbers in this assay, from the lowest: compounds 1, 2 and 4 (each within the scatter of the next); then compound 3.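

In this assay, fluoro in place of hydrogen at this carbon, ortho to a fused ring and meta to a chloro group, gives no change at the digits printed from compound 1 to compound 4 (within the scatter). The same kind of change at another carbon of the core had also left the number where it was, so the outcome now holds at two places rather than one. Both steps start from compound 1, whose number is as low as any seen here, so neither shows what this fluoro does on a compound that is removed faster, such as compound 3.

Nothing measured on these compounds explains why the number stays put. Also open, from the compounds shown here alone, is whether a larger group at this carbon, such as methoxy or an amine, would leave the number just as unchanged.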